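This account rests on a few compounds, and the source may have more. Where it says the series, first, only, none or still open, it means among the compounds named here.

Measured compounds, with their values in an assay on Y-1 cells for inhibition of Alpha-2B adrenergic receptor (Homo sapiens); a lower number here means a stronger inhibitor, a higher number a weaker inhibitor:
- compound 1 `c1ccc(CCC[C@H]2C3CCC(C3)[C@H]2NC2=NCCO2)cc1`: 141 nM
- compound 2 `CCC[C@H]1C2CCC(C2)[C@H]1NC1=NCCO1`: 91.2 nM
- compound 3 `c1ccc(CCC[C@H]2CCCC[C@@H]2NC2=NCCO2)cc1`: 32.4 nM

Compound 2 stands second highest of the three numbers in this assay; its nearest neighbour is compound 1, a step that lies within the scatter, and the furthest is compound 3, whose number is lower by a margin beyond the scatter.

Compound 4 `c1ccc(C[C@H]2C3CCC(C3)[C@H]2NC2=NCCO2)cc1` has not yet been measured. It differs from compound 2 by phenyl in place of ethyl on a saturated chain carbon bound to a saturated ring carbon. Among the measured compounds shown here, the only measured step that touches the same chain is a 1.5-fold lower number from compound 1 to compound 2 (0.19 log units; within the scatter), where the phenyl sat three bonds along the chain rather than on the chain carbon bound to the ring carbon. That step gave no movement beyond the scatter. For the measured compounds named here, compound 3 carries the phenyl on the longer chain with a different core, so it gives no step to compound 2 or compound 4 and only shows that its own number is lower than that of compound 2.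

Going by the values given here, with no direct precedent for a phenyl placed this close to the ring, the expected step in this assay is a 1.1-fold higher number from compound 2 to compound 4 (0.04 log units; within the scatter), not clearly beyond the scatter in either direction. Compound 4 is therefore estimated at 100 nM, with a range from 30 nM to 330 nM.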

Compound 4, inhibition constant: 40.7 nM
Compound 4: middle estimate off by 2.5-fold (0.39 log units), on the high side; the range from low to high includes it.
By their numbers in this assay, from the lowest: compounds 3 and 4 (each within the scatter of the next); then compounds 2 and 1 (each within the scatter of the next).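

In this assay, phenyl in place of ethyl on a saturated chain carbon bound to a saturated ring carbon gives a 2.2-fold lower number from compound 2 to compound 4 (0.35 log units; beyond the scatter), so this chain carbon accepts the phenyl with a modest move towards a stronger inhibitor. Among the compounds shown here, the earlier step on this chain, a 1.5-fold lower number from compound 1 to compound 2 (0.19 log units; within the scatter), stayed within the scatter, and the present change is the first on the shared core to move beyond it. No measurement available bears on the cause of this step.

The compounds shown leave open how a cyclohexyl or a pyridyl group would compare with phenyl on this chain carbon. They also leave open whether the same change would give a step of like size on the core of compound 3, which stands at 32.4 nM with its longer chain.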